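A few compounds are considered here, and "the series" means these few. Any claim that something is new, unique, unknown or untested is made for them only; others in the source may bear on it.

Compound 1 `CCCCCCCCCCCC(=O)N[C@H](CCC(=O)NC(CCCC(N)C(=O)O)C(=O)O)C(=O)O`: 0.027 nM
Compound 2 `CCCCCCCCCCCC(=O)N[C@H](CCC(=O)NC(CCCC1NC(N)=NC1=O)C(=O)O)C(=O)O`: 1.31 nM
Compound 3 `CCCCCCCCCCCC(=O)N[C@H](CCC(=O)NC(CCCCC(=O)O)C(=O)O)C(=O)O`: > 100 nM

In a functional assay on HEK293 cells for agonist activity at Nucleotide-binding oligomerization domain-containing protein 1 (Homo sapiens), read by spectrophotometry (a higher number here means that more compound is needed for the effect, a lower number that less compound is needed), compound 3 gives only a limit, > 100 nM, so its true value is not known (the limit of > 100 nM in this assay, at which 1 of the 3 values shown sits). Compound 4 `CCCCCCCCCCCC(=O)N[C@H](CCC(=O)NCCCC[C@H](N)C(=O)O)C(=O)O` differs from compound 3 by a group of 9 heavy atoms (6 carbon, 1 nitrogen, 2 oxygen; no ring) in place of a group of 11 heavy atoms (7 carbon, 4 oxygen; no ring), on an amide-type nitrogen. This restores the free amino group and removes one carboxylic acid. The measured steps show how much the amino group matters: an at least 3700-fold higher number from compound 1 to compound 3 (3.56 log units; beyond the scatter), and a 49-fold higher number from compound 1 to compound 2 (1.69 log units; beyond the scatter). Compound 4 carries that amino group again, so a large step toward a lower number in this assay is expected, an at least 66-fold lower number from compound 3 to compound 4 (1.82 log units; beyond the scatter), though loss of the carboxylic acid leaves it short of compound 1. The estimate for compound 4 is 1.5 nM, within 0.1 nM to 30 nM.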

Compound 4, half-maximal effective concentration: 0.96 nM
For compound 4 the middle estimate is 1.6-fold (0.19 log units) above the measured one; low and high end bracket the measured number.
By their numbers in this assay, from the lowest: compound 1; then compounds 4 and 2 (each within the scatter of the next). At a limit, above all of these: compound 3.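

Compound 3 gives only a limit, > 100 nM, in this assay. Even so, an at least 100-fold lower number from compound 3 to compound 4 (2.01 log units; beyond the scatter) shows that 5-amino-5-carboxypentyl on the amide-type nitrogen is enough to give a low number, although it carries one carboxylic acid fewer than the group it replaces. This single change both adds an amino group and removes a carboxylic acid, so the step cannot be divided between the two. As far as these compounds go, it remains open whether a longer chain carrying the amine, or an amine with no carboxylic acid on that chain, would keep this level.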